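The source may report more compounds than this note shows. Statements on the series, on what has been measured and on what is new or still open speak of the compounds shown alone.

Compound 1 `O=C(C1CCCN1)N1CCC2(CCN(c3nccc(NCc4ccc(Cl)cc4Cl)n3)CC2)C1` carries a (pyrrolidin-2-yl)carbonyl group on the amine nitrogen in a ring of the shared core. Among the compounds with values here, in a physicochemical assay for solubility, read by chemiluminescence, measured as kinetic solubility (on this read-out lower numbers stand for lower solubility and higher numbers for higher solubility), compound 1 gives 79 ug/mL, the lowest of the three numbers so far. Compound 2 `O=C([C@@H]1CCCCN1)N1CCC2(CCN(c3nccc(NCc4ccc(Cl)cc4Cl)n3)CC2)C1` gives 170 ug/mL and compound 3 `O=C(C1CCCNC1)N1CCC2(CCN(c3nccc(NCc4ccc(Cl)cc4Cl)n3)CC2)C1` gives 186 ug/mL; both carry a six-membered ring in place of the five-membered one, with a 2.2-fold higher number from compound 1 to compound 2 (0.33 log units; beyond the scatter) and a 2.4-fold higher number from compound 1 to compound 3 (0.37 log units; beyond the scatter), while a 1.1-fold higher number from compound 2 to compound 3 (0.04 log units; within the scatter). Compound 4 `Clc1ccc(CNc2ccnc(N3CCC4(CCN(CC5CCCCN5)C4)CC3)n2)c(Cl)c1` differs from compound 1 as follows: (piperidin-2-yl)methyl in place of (pyrrolidin-2-yl)carbonyl on an amine nitrogen in a ring. Within the data shown here, its six-membered ring parallels compounds 2 and 3, but no measured step removes the carbonyl, so that part of the change is untested. A modest rise is expected, a 1.9-fold higher number from compound 1 to compound 4 (0.28 log units; within the scatter), with wide uncertainty. Compound 4 is therefore estimated at 150 ug/mL in this assay, within 60 ug/mL to 350 ug/mL.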

Compound 4, solubility: 182 ug/mL
Estimate against measurement, compound 4: 1.2-fold (0.08 log units) below; the range from low to high includes it.
By their numbers in this assay, from the lowest: compound 1; then compounds 2, 4 and 3 (each within the scatter of the next).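

With the ring held as piperidin-2-yl, removing the carbonyl oxygen leaves the number unchanged within the scatter in this assay, a 1.1-fold higher number from compound 2 to compound 4 (0.03 log units; within the scatter), so at this position the carbonyl is not required for the level of compound 2. Compound 4 also sits level with compound 3, a 1.0-fold lower number from compound 3 to compound 4 (0.01 log units; within the scatter), while the change from compound 1 is a 2.3-fold higher number from compound 1 to compound 4 (0.36 log units; beyond the scatter), which combines ring size and linker in one step. No measurement on hand accounts for these numbers.

Open, as far as these compounds go, is whether (pyrrolidin-2-yl)methyl on the same nitrogen would stay near compound 1 or reach the level of compound 4, which would separate ring size from linker. Also open, from the compounds shown here alone, is how an open-chain amine or a longer chain carrying the piperidine would read here.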